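Replacing the Methoxyethyl Ether on the Shared Core

This account rests on a few compounds, and the source may have more. Where it says the series, first, only, none or still open, it means among the compounds named here.

In an assay on HEK293 cells for inhibition of kynurenine 3-monooxygenase (Homo sapiens), read by LC-MS, with a stated time of 20 h (a higher number here means a weaker inhibitor, a lower number a stronger inhibitor), compound 3 `COCCOc1cc2oc(=O)n(CCC(=O)O)c2cc1Cl` gives 50100 nM, the highest of the three numbers measured. Compound 1 `O=C(O)CCn1c(=O)oc2cc(OCc3ccccc3)c(Cl)cc21` gives 1580 nM and compound 2 `CCOc1cc2oc(=O)n(CCC(=O)O)c2cc1Cl` gives 398 nM, so the steps of a 32-fold higher number from compound 1 to compound 3 (1.50 log units; beyond the scatter) and a 130-fold higher number from compound 2 to compound 3 (2.10 log units; beyond the scatter) both run strongly against compound 3. Compound 4 `C[C@@H](Oc1cc2oc(=O)n(CCC(=O)O)c2cc1Cl)c1ncccn1` differs from compound 3 by a group of 8 heavy atoms (6 carbon, 2 nitrogen; one six-membered aromatic ring with 2 hetero atoms) in place of a group of 4 heavy atoms (3 carbon, 1 oxygen; no ring), on an oxygen on an aromatic ring. The step of a 32-fold higher number from compound 1 to compound 3 (1.50 log units; beyond the scatter) shows that a phenyl on the saturated chain carbon bound to the ring oxygen gives a far lower number than the methoxymethyl, and a 4.0-fold lower number from compound 1 to compound 2 (0.60 log units; beyond the scatter) shows a methyl there gives a lower number still; compound 4 brings a six-membered aromatic ring into this position. A large drop in this assay is therefore expected for compound 4, a 50-fold lower number from compound 3 to compound 4 (1.70 log units; beyond the scatter). Compound 4 is estimated at 1000 nM, within 250 nM to 5000 nM.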

Compound 4, half-maximal inhibitory concentration: 3160 nM
The estimate for compound 4 lay 3.2-fold (0.50 log units) below the measured number; the measured number falls inside the stated range.
By their numbers in this assay, from the lowest: compound 2; then compounds 1 and 4 (each within the scatter of the next); then compound 3.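

In this assay the ring-bearing group on the oxygen recovers much of what the 2-methoxyethyl group gives up, with a 16-fold lower number from compound 3 to compound 4 (1.20 log units; beyond the scatter) for this change. Pyrimidin-2-yl on the chain carbon is still not tolerated as well as hydrogen, with a 7.9-fold higher number from compound 2 to compound 4 (0.90 log units; beyond the scatter) on that comparison. Set against the carbon-only ring, a 2.0-fold higher number from compound 1 to compound 4 (0.30 log units; within the scatter) lies within the scatter, so the two rings cannot be told apart here. Nothing shown gives a reason for these steps. On these data alone, whether the defined stereocentre matters stays open, as does whether an amine or a longer chain on this oxygen would give a lower number than compound 2.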